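The compounds below may be only part of what the source reports. "The series", "measured", "known", "first", "only" and "open" are said of these compounds alone.

Three macrolide compounds have been measured in a physicochemical assay for lipophilicity, read by HPLC, measured as chromatographic lipophilicity, at pH 7.4; on this read-out lower numbers stand for lower lipophilicity and higher numbers for higher lipophilicity. Compound 1, with the structure `CC[C@H]1OC(=O)[C@H](C)[C@@H](O[C@H]2C[C@@](C)(OC)[C@@H](O)[C@H](C)O2)[C@H](C)[C@@H](O[C@@H]2O[C@H](C)C[C@H](N(C)C)[C@H]2O)[C@](C)(O)C[C@@H](C)CN(C)[C@H](C)[C@@H](OCCCNC(=O)C2CCC2)[C@]1(C)O`, gives 3.5 in this assay. Compound 2, with the structure `CC[C@H]1OC(=O)[C@H](C)[C@@H](O[C@H]2C[C@@](C)(OC)[C@@H](OCCCNC(C)=O)[C@H](C)O2)[C@H](C)[C@@H](O[C@@H]2O[C@H](C)C[C@H](N(C)C)[C@H]2O)[C@](C)(OC)C[C@@H](C)C(=O)[C@H](C)[C@@H](O)[C@]1(C)O`, gives 3.08 in this assay. Compound 3, with the structure `CC[C@H]1OC(=O)[C@H](C)[C@@H](O[C@H]2C[C@@](C)(OC)[C@@H](OCCCNC(C)=O)[C@H](C)O2)[C@H](C)[C@@H](O[C@@H]2O[C@H](C)C[C@H](N(C)C)[C@H]2O)[C@](C)(O)C[C@@H](C)CN(C)[C@H](C)[C@@H](O)[C@]1(C)O`, gives 2.06 in this assay. Among the three numbers compound 1 stands highest; compound 2 is nearest to it, lower by a gap that is beyond the scatter, and compound 3 is furthest, lower by a gap that is also beyond the scatter. Among the measured compounds shown here, no single-point step between two measured compounds is available, so no measured step can be quoted.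

Compound 4, with the structure `CC[C@H]1OC(=O)[C@H](C)[C@@H](O[C@H]2C[C@@](C)(OC)[C@@H](O)[C@H](C)O2)[C@H](C)[C@@H](O[C@@H]2O[C@H](C)C[C@H](N(C)C)[C@H]2O)[C@](C)(O)C[C@@H](C)CN(C)[C@H](C)[C@@H](OCCCNC(C)=O)[C@]1(C)O`, has not yet been measured in this assay. It differs from compound 1 in one place: methyl in place of cyclobutyl on a carbonyl carbon. A four-membered ring thus leaves and a single methyl enters on the same carbonyl carbon.

Since a smaller group replaces a larger one, compound 4 is expected to come out lower than compound 1, by a step well beyond the scatter, estimated as a number 1.00 log units lower from compound 1 to compound 4 (beyond the scatter). Starting from the value of compound 1 at 3.5, compound 4 is expected to give about 2.5 in this assay, most likely between 2 and 3.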

Compound 4, distribution coefficient: 2.41
For compound 4 the middle estimate is 0.09 log units above the measured one; the range from low to high includes it.
By their numbers in this assay, from the lowest: compound 3; then compound 4; then compound 2; then compound 1.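

In this assay, among the compounds shown here, the change of cyclobutyl to methyl on a carbonyl carbon gives the first single-place step in this set, a number 1.09 log units lower from compound 1 to compound 4 (beyond the scatter), so the group at this position clearly affects the read-out. Neither group carries a hydrogen-bond donor, a hydrogen-bond acceptor or a net charge, and both are built of carbon only, so a large step can arise here without any change in those counts. Nothing available explains the size of this step.

With only one pair at this position, the compounds shown cannot tell whether the read-out follows the size of the group in an orderly way, as ethyl, isopropyl or cyclopentyl on the same carbonyl carbon could show, or whether a ring matters in its own right, as a straight butyl chain could show. They also leave open what an amine or a carboxylic acid would do there, and whether the same change from cyclobutylcarbonyl to acetyl gives a similar step on a different core.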